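The source may hold more compounds than are shown below. What is called first, only, known or untested is meant among the compounds shown, and "the series" means these compounds.

Compound 3, `CN(C)CCCOCc1c(F)c(N)c2c(=O)cc(-c3ccc(N)c(F)c3)oc2c1F`, holds the lowest of the two numbers read in a functional assay on HeLa cells (Homo sapiens) for cytotoxicity, read by neutral red uptake, with a stated time of 3 days; on this read-out higher numbers stand for weaker inhibition and lower numbers for stronger inhibition: compound 3 gives 12000 nM. Compound 2, `CCC(=O)OCc1c(F)c(N)c2c(=O)cc(-c3ccc(N)c(F)c3)oc2c1F`, gives 69000 nM in this assay, so that the step of a 5.8-fold lower number from compound 2 to compound 3 (0.76 log units; beyond the scatter) lies beyond the scatter. Compound 1, `CN(C)c1c(F)c(N)c2c(=O)cc(-c3ccc(N)c(F)c3)oc2c1F`, reaches only a limit in this assay, > 100000 nM, which is the limit described as the limit of > 100000 nM in this assay, at which 1 of the 3 values shown sits. The steps measured so far, an at least 1.4-fold lower number from compound 1 to compound 2 (0.16 log units; that floor lies within the scatter) and an at least 8.3-fold lower number from compound 1 to compound 3 (0.92 log units; beyond the scatter), point the same way, with the longer basic chain of compound 3 giving the larger move.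

Compound 4, `CN(C)Cc1c(F)c(N)c2c(=O)cc(-c3ccc(N)c(F)c3)oc2c1F`, differs from compound 3 in one place: dimethylamino in place of 3-(dimethylamino)propoxy on a saturated chain carbon bound to an aromatic carbon. The change removes the three-carbon linker and the oxygen but keeps a dimethylamino group attached through a saturated carbon, unlike compound 1, whose dimethylamino sits directly on the aromatic carbon. Within the data shown here, only the step from compound 2 to compound 3 bears directly on the value of the basic chain, and it was modest; the shorter arm of compound 4 is expected to give back part of that gain, so compound 4 is estimated to show a step of a 2.1-fold higher number from compound 3 to compound 4 (0.32 log units; beyond the scatter) in this assay. Compound 4 is therefore expected to come out near 25000 nM, with a range from 8000 nM to 80000 nM.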

Compound 4, half-maximal inhibitory concentration: 8900 nM
Beside the measured number, compound 4's estimate is 2.8-fold (0.45 log units) above it; measured number inside the range.
By their numbers in this assay, from the lowest: compounds 4 and 3 (each within the scatter of the next); then compound 2. At a limit, above all of these: compound 1.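

In this assay, the shorter arm gives a 1.3-fold lower number from compound 3 to compound 4 (0.13 log units; within the scatter), so compounds 3 and 4 cannot be told apart and the full 3-(dimethylamino)propoxy arm is not needed to reach this level, while dimethylamino in place of propanoyloxy gives a 7.8-fold lower number from compound 2 to compound 4 (0.89 log units; beyond the scatter), a step beyond the scatter that needs no propoxy linker. The earlier compounds also left open whether a dimethylamino group alone could account for a step from compound 1, and setting it on a saturated chain carbon bound to an aromatic carbon gives an at least 11-fold lower number from compound 1 to compound 4 (1.05 log units; beyond the scatter), which shows that the same group behaves differently on the saturated carbon than directly on the aromatic carbon. That step is only a floor, since compound 1 stands at a limit and not at a measured number: the limit of > 100000 nM in this assay, at which 1 of the 4 values shown sits.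

The compounds shown leave open whether a primary amine, a piperidine or a morpholine on that saturated chain carbon would match compound 4. They also leave open how a carboxylic acid would read there, and whether a two-carbon chain ending in dimethylamino would fall in line with compounds 3 and 4.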